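Aziridinyl amide in place of difluoropropyl amide

The source may report more compounds than this note shows. Statements on the series, on what has been measured and on what is new or still open speak of the compounds shown alone.

Compound 2 `Cc1cc(/C=C/C#N)cc(C)c1Oc1cc(Nc2ccc(C#N)cc2)c(N)cc1C(=O)NCCC(F)F` holds the lower of the two half-lives known in an ADME assay on liver (Homo sapiens) for metabolic stability, read by LC-MS, using S9 fraction and NADPH, with a stated time of 45 min, tested at 1 uM; on this read-out higher numbers stand for a longer-lived compound and lower numbers for a shorter-lived compound: compound 2 gives 0.233 h, while compound 1 `Cc1cc(/C=C/C#N)cc(C)c1Oc1cc(Nc2ccc(C#N)cc2)c(N)cc1C(N)=O` gives 1.8 h. Among the measured compounds shown here, the one step measured so far, a 7.7-fold lower number from compound 1 to compound 2 (0.89 log units; beyond the scatter), is the only one that bears on the next change. Compound 3 `Cc1cc(/C=C/C#N)cc(C)c1Oc1cc(Nc2ccc(C#N)cc2)c(N)cc1C(=O)N1CC1` differs from compound 2 in that (aziridin-1-yl in place of (3,3-difluoropropyl)amino on a carbonyl carbon). For the measured compounds named here, since the 3,3-difluoropropyl group that leaves is the same group whose arrival shortened the half-life from compound 1 to compound 2, part of that loss might be recovered, but the aziridine that enters also has no measured counterpart, so the size of the step is uncertain. He therefore expects a modest rise, a 2.1-fold higher number from compound 2 to compound 3 (0.33 log units; beyond the scatter), with a wide range. The estimate for compound 3 in this assay is 0.5 h, between 0.15 h and 1.8 h.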

Compound 3, half-life: 1.83 h
The estimate for compound 3 lay 3.7-fold (0.56 log units) below the measured number; measured number outside the range, above it.
By their numbers in this assay, from the lowest: compound 2; then compounds 1 and 3 (each within the scatter of the next).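

In this assay, the carbonyl carbon carries a group other than amino with no cost in half-life: aziridin-1-yl in place of (3,3-difluoropropyl)amino gives a 7.9-fold higher number from compound 2 to compound 3 (0.90 log units; beyond the scatter), while aziridin-1-yl in place of amino gives a 1.0-fold higher number from compound 1 to compound 3 (0.01 log units; within the scatter). The short half-life of compound 2 therefore does not extend to every substituent on this amide nitrogen among the three compounds, since compound 3 stands within the scatter of compound 1. No measurement available here explains the difference.

From the compounds shown here alone, it remains open whether the fluorine atoms, the open chain or the three-membered ring accounts for the step. A plain propyl amide and an azetidin-1-yl amide on the same carbonyl carbon would help separate these possibilities.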